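A Cyanophenyl Replacing a Chlorophenyl in Compound 4

A few compounds are considered here, and "the series" means these few. Any claim that something is new, unique, unknown or untested is made for them only; others in the source may bear on it.

Compound 1, `O=C(Nc1ccc(Br)cc1)N1CCC[C@H]1c1nc(-c2ccccc2)no1`, compound 2, `O=C(Nc1ccc(I)cc1)N1CCC[C@H]1c1nc(-c2ccccc2)no1`, and compound 3, `O=C(Nc1ccc(Cl)cc1)N1CCC[C@H]1c1nc(-c2cccc(Cl)c2)no1`, share one core and were each tested in an ADME assay on MCF-10A cells (Homo sapiens) for inhibition, with a stated time of 48 h; on this read-out higher numbers stand for weaker inhibition and lower numbers for stronger inhibition. For compound 1 the result is only a limit of the assay, > 50000 nM, not a number. For compound 2 the result is likewise a limit of the assay, > 50000 nM. For compound 3 the result is again a limit of the assay, > 50000 nM. Among the compounds with values here, the only one-place step among them, a step that the two limits leave unreadable from compound 1 to compound 2, therefore cannot be given a size. Compound 3 stands exactly where every measured compound stands, namely at the limit of > 50000 nM in this assay, at which 3 of the 3 values shown sit. Compound 4, `N#Cc1ccc(-c2noc([C@@H]3CCCN3C(=O)Nc3ccc(Cl)cc3)n2)cc1`, differs from compound 3 in one place: 4-cyanophenyl in place of 3-chlorophenyl on an aromatic carbon. Within the data shown here, no measured step involves this particular change, and the single step that exists yields no size, so no movement in this assay is expected beyond another limit. Compound 4 is expected to give 60000 nM, estimated between 15000 nM and 250000 nM, meaning an expected step that the limit leaves unreadable from compound 3 to compound 4.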

Compound 4, half-maximal inhibitory concentration: > 50000 nM
Compound 4: a limit, no number (the forecaster's own chance of this, stated with the estimate: 80%); the middle value does not contradict the limit.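

Compound 3 and compound 4 both give a limit in this assay, not a number, so the step between them cannot be read: the limit of > 50000 nM in this assay, at which 4 of the 4 values shown sit.

The compounds shown leave open at what concentration, if any, each one inhibits, and how far any single change moves that concentration.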